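The source may hold more compounds than are shown below. What is called first, only, known or untested is meant among the compounds shown, and "the series" means these compounds.

In an ADME assay on microsomes from liver (Homo sapiens) for metabolic stability, with a stated time of 30 min (a higher number here means that more of the compound is left, a lower number that less of the compound is left), compound 3 `CCCCc1nc(C)c(CC(=O)OC)c(=O)n1Cc1ccc(-c2ccccc2-c2noc(=O)[nH]2)cc1` gives 69.6%, the highest of the two numbers available there. Going by the values given here, its nearest neighbour, compound 1 `CCCCc1nc(C(C)C)c(CC(=O)OC)c(=O)n1Cc1ccc(-c2ccccc2-c2noc(=O)[nH]2)cc1`, gives 10.5%; the difference, a number 59.1 percentage points higher from compound 1 to compound 3 (beyond the scatter), is the only measured step in the set. For compound 2 `CCCCc1nc(C(C)C)c(CC(=O)OCC(F)(F)F)c(=O)n1Cc1ccc(-c2ccccc2-c2noc(=O)[nH]2)cc1` the entry in this assay reads "not determined" (no result reported), so no result was reported. Compound 4 `CCCCc1nc(C)c(CC(=O)OC2CC2)c(=O)n1Cc1ccc(-c2ccccc2-c2noc(=O)[nH]2)cc1` differs from compound 3 by cyclopropyl in place of methyl on an oxygen next to a carbonyl group. Among the compounds with values here, no measured step touches the ester oxygen, so the one known step, which concerns the aromatic carbon, does not bear on this change and offers no direction. With no direct evidence, a step of moderate size downward is estimated, a number 14.6 percentage points lower from compound 3 to compound 4 (beyond the scatter). Compound 4 is therefore expected to give about 55% in this assay, within a range from 30% to 80%.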

Compound 4, percent of the compound remaining: 34.5%
Estimate against measurement, compound 4: 20.5 percentage points above, and the stated range covers the measured number.
By their numbers in this assay, from the lowest: compound 1; then compound 4; then compound 3.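

Going by these compounds alone, the ester oxygen, which no earlier step touched, proves to be a sensitive place in this assay: cyclopropyl in place of methyl on this oxygen gives a number 35.1 percentage points lower from compound 3 to compound 4 (beyond the scatter). This shows that a change in the ester group alone, with the methyl on the aromatic carbon kept, moves the number by a large step. Nothing shown accounts for this drop. The compounds shown leave open how an ethyl ester or a tert-butyl ester would compare with compound 3 and compound 4. They also leave open how a carboxylic acid or an amide would behave in place of the ester.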